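Thiophene dihydropyrimidinone esters: oxygen ester returns

The compounds below may be only part of what the source reports. "The series", "measured", "known", "first", "only" and "open" are said of these compounds alone.

Measured compounds:
Compound 1 `CCCOC(=O)C1=C(C)NC(=O)NC1c1cccs1`: 43%
Compound 2 `CCSC(=O)C1=C(C)NC(=O)NC1c1cccs1`: 6%

In an assay on membranes from CHO cells for displacement of a labelled ligand from adenosine receptor A1 (Homo sapiens), read by scintillation counting, with a stated time of 60 min, tested at 1 uM (a lower number here means less inhibition, a higher number more inhibition at the concentration tested (going by the name of the read-out)), compound 1 gives 43%, and compound 2 gives 6%. Going by the values given here, compound 2 thus stands lowest of the two numbers measured so far; its nearest neighbour is compound 1, and the step of a number 37 percentage points lower from compound 1 to compound 2 (beyond the scatter) is well beyond the scatter.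

Compound 3 `CC1=C(C(=O)OC2CCCC2)C(c2cccs2)NC(=O)N1` differs from compound 2 in one place: cyclopentyloxy in place of ethylsulfanyl on a carbonyl carbon. Among the compounds with values here, the only measured step that bears on this change is the one from compound 1 to compound 2, in which an ethylsulfanyl group replaced an alkoxy group on the same carbonyl carbon and the number fell sharply, a number 37 percentage points lower from compound 1 to compound 2 (beyond the scatter). Compound 3 reverses that exchange, putting an alkoxy group back, though with a cyclopentyl rather than a propyl chain, for which no measured comparison exists.

Within the data shown here, a step upward is therefore expected, of a size near the one seen from compound 1 to compound 2, estimated as a number 34 percentage points higher from compound 2 to compound 3 (beyond the scatter). Compound 3 is expected to give 40% in this assay, within a range of 15% to 65%.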

Compound 3, a percentage reported as inhibition, at one concentration (the size of the read-out at that concentration, not a potency): 9%
Compound 3: the middle estimate sits 31 percentage points above what was measured; the measured number lies below the stated range.
By their numbers in this assay, from the lowest: compounds 2 and 3 (each within the scatter of the next); then compound 1.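

Notes on the group on the carbonyl carbon: in this assay, cyclopentyloxy in place of ethylsulfanyl gives a number 3 percentage points higher from compound 2 to compound 3 (within the scatter), so an oxygen at this place does not by itself bring back the number of compound 1. The group carried on that oxygen also counts, since cyclopentyl in place of propyl gives a number 34 percentage points lower from compound 1 to compound 3 (beyond the scatter), a large step between two oxygen esters on the same core. The earlier step, a number 37 percentage points lower from compound 1 to compound 2 (beyond the scatter), changed both the linking atom and the group attached to it, and it can no longer be read as an effect of the sulfur atom alone.

Ethoxy and propylsulfanyl would each separate those two changes, the first matching the ethyl group of compound 2 on an oxygen and the second matching the propyl group of compound 1 on a sulfur. As far as these compounds go, whether the higher number of compound 1 is tied to an open chain in general or to propyl in particular stays open, and a butoxy group or a branched isopropoxy group would bear on that. No measurement shown here explains any of these steps.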